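Benzothiazole amide series: cytotoxicity read-out

The compounds below may be only part of what the source reports. "The series", "measured", "known", "first", "only" and "open" are said of these compounds alone.

Measured compounds:
compound 1 `Cn1ncc([N+](=O)[O-])c1C(=O)Nc1ccc2nc(NC(=O)C3CCCCC3)sc2c1`: 0.026 ug/mL
compound 2 `O=C(Nc1ccc2nc(NC(=O)C3CCCCC3)sc2c1)c1ccccc1Cl`: 0.025 ug/mL
compound 3 `N#Cc1ccc(C(=O)Nc2ccc3nc(NC(=O)C4CCCCC4)sc3c2)cc1`: 3.3 ug/mL

In a functional assay on WI-38 VA13 cells (Homo sapiens) for cytotoxicity (on this read-out higher numbers stand for an effect only at larger amounts of compound and lower numbers for an effect already at smaller amounts), compound 3 gives the highest of the three numbers. The two measured steps onto it are large: a 130-fold higher number from compound 1 to compound 3 (2.10 log units; beyond the scatter) and a 130-fold higher number from compound 2 to compound 3 (2.12 log units; beyond the scatter). Compound 1 and compound 2 lie within the scatter of each other, shown by a 1.0-fold lower number from compound 1 to compound 2 (0.02 log units; within the scatter).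

Compound 4 `C=CCOC(=O)Nc1ccc2nc(NC(=O)C3CCCCC3)sc2c1` differs from compound 3 only at the carbonyl carbon: allyloxy in place of 4-cyanophenyl on a carbonyl carbon. Among the measured compounds shown here, no measured step covers an allyloxy group there, so the only guidance is that the group on this carbonyl has moved the number strongly in both measured steps. A step in either direction is possible; an intermediate outcome is expected, a 4.1-fold lower number from compound 3 to compound 4 (0.62 log units; beyond the scatter), giving an estimate for compound 4 of 0.8 ug/mL within 0.08 ug/mL to 8 ug/mL.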

Compound 4, half-maximal effective concentration: 0.58 ug/mL
Compound 4: middle estimate off by 1.4-fold (0.14 log units), on the high side, and the stated range covers the measured number.
By their numbers in this assay, from the lowest: compounds 2 and 1 (each within the scatter of the next); then compound 4; then compound 3.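

In this assay, allyloxy brings a group without a ring onto this carbonyl carbon, and the number falls inside the span set by the three ring-bearing groups: a 5.7-fold lower number from compound 3 to compound 4 (0.76 log units; beyond the scatter), while a 23-fold higher number from compound 2 to compound 4 (1.37 log units; beyond the scatter) and a 22-fold higher number from compound 1 to compound 4 (1.35 log units; beyond the scatter). A ring on this carbonyl carbon is therefore not required for a number below that of compound 3, but the two lowest numbers still belong to ring-bearing groups.

No available data explain these steps. Going by these compounds, whether an amine or a longer alkoxy chain on this carbonyl carbon would give a number near that of compound 4 remains open.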